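Removing a Methyl Group from the Weakest Compound

The source may hold more compounds than are shown below. What is called first, only, known or untested is meant among the compounds shown, and "the series" means these compounds.

Measured so far:
compound 1, `COc1c(/C=C2/C(=O)Nc3ccc(Cl)cc32)c2ccccc2n1-c1ccccc1`: 5250 nM
compound 2, `COc1cc2c(cc1C)NC(=O)/C2=C/c1c(Cl)n(Cc2cc(OC)c(OC)c(OC)c2)c2cc(C)c(OC)cc12`: 49000 nM
compound 3, `O=C1/C(=C/c2c(Cl)[nH]c3ccccc23)c2ccccc2N1Cc1ccccc1`: 4900 nM

Of the compounds shown here, three have been tested in a functional assay on cells (Cancer cell lines, Homo sapiens) for cytotoxicity, with a stated time of 48 h; on this read-out higher numbers stand for weaker inhibition of growth and lower numbers for stronger inhibition of growth. Compound 2 stands at the highest number of the three, which on this read-out means the weakest inhibition of growth. Its gap to compound 1 and its gap to compound 3 both lie beyond the usual scatter of repeated measurements, so compound 2 is clearly the least active of the compounds measured. Among the measured compounds shown here, no pair among the three differs in only one place, so no single-change step can be read off from the measured numbers.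

Compound 4, `COc1ccc2c(c1)/C(=C\c1c(Cl)n(Cc3cc(OC)c(OC)c(OC)c3)c3cc(C)c(OC)cc13)C(=O)N2`, has not yet been tested. It differs from compound 2 in one place: hydrogen in place of methyl on an aromatic carbon. A methyl leaves and a hydrogen enters, on an aromatic carbon of a six-membered aromatic ring of carbon only, ortho to a methoxy group.

Because compound 2 gives 49000 nM in this assay and the change is the loss of a single carbon, the step is expected to be small, most likely within the scatter, with at best a slight move toward stronger inhibition; the expected step is a 1.4-fold lower number from compound 2 to compound 4 (0.15 log units; within the scatter). For compound 4 the estimated value in this assay is 35000 nM, with a range from 12000 nM to 100000 nM.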

Compound 4, concentration for 50% growth inhibition: 16200 nM
The estimate for compound 4 lay 2.2-fold (0.33 log units) above the measured number; low and high end bracket the measured number.
By their numbers in this assay, from the lowest: compounds 3 and 1 (each within the scatter of the next); then compound 4; then compound 2.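

In this assay, taking away the methyl group on the aromatic carbon ortho to a methoxy group gives a 3.0-fold lower number from compound 2 to compound 4 (0.48 log units; beyond the scatter), a modest step but one that lies beyond the scatter, so the loss of this single carbon is enough to change the read-out. Among the compounds shown here, this is the first direct comparison in the set, since it is the first pair of compounds differing in only one place, and it shows that this position is not silent: hydrogen here goes with stronger inhibition of growth than methyl does. The data give no measured property that could explain the shift, so the step can be reported but its cause cannot be assigned.

For the compounds shown here, with only one pair carrying this change, it remains open whether the same step would appear on a different core or with other groups elsewhere on the molecule. Also unknown is how an amine, a hydroxyl group or a longer chain such as ethyl would behave on this carbon, and so whether hydrogen is the best choice here or merely better than methyl.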